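The source may report more compounds than this note shows. Statements on the series, on what has been measured and on what is new or still open speak of the compounds shown alone.

- Compound 1 `O=C1c2c[n+]([O-])c3ccccc3c2C(=O)c2c1c1ccccc1n2CCCCN1CCCCC1`: 190 nM
- Compound 2 `CCCN1CCN(CCCCn2c3c(c4ccccc42)C(=O)c2c[n+]([O-])c4ccccc4c2C3=O)CC1`: 870 nM

In a functional assay on A-375 cells (Homo sapiens) for cytotoxicity, read by MTT assay, with a stated time of 72 h (on this read-out higher numbers stand for weaker inhibition and lower numbers for stronger inhibition), compound 2 gives the higher of the two numbers, 870 nM. Compound 3 `CN1CCN(CCCn2c3c(c4ccccc42)C(=O)c2c[n+]([O-])c4ccccc4c2C3=O)CC1` differs from it by 4-methylpiperazin-1-yl in place of (4-propylpiperazin-1-yl)methyl on a saturated chain carbon, three bonds along the chain from an aromatic nitrogen. In words, 4-methylpiperazin-1-yl stands in place of (4-propylpiperazin-1-yl)methyl on a saturated chain carbon, three bonds along the chain from an aromatic nitrogen. Going by the values given here, the only measured step that bears on this is a modest one, a 4.6-fold higher number from compound 1 to compound 2 (0.66 log units; beyond the scatter), and no change of chain alone has been measured. A small move to a lower number is therefore expected in this assay, perhaps none beyond the scatter. The expected size is a 1.5-fold lower number from compound 2 to compound 3 (0.16 log units; within the scatter). Compound 3 is estimated at 600 nM, with a range of 200 nM to 1800 nM.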

Compound 3, half-maximal inhibitory concentration: 470 nM
The estimate for compound 3 lay 1.3-fold (0.11 log units) above the measured number, within the range that was stated.
By their numbers in this assay, from the lowest: compound 1; then compounds 3 and 2 (each within the scatter of the next).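

In this assay the step to 4-methylpiperazin-1-yl on this chain gives a 1.9-fold lower number from compound 2 to compound 3 (0.27 log units; within the scatter) and so does not separate the two piperazine compounds. The piperidine compound still stands apart, with a 2.5-fold higher number from compound 1 to compound 3 (0.39 log units; beyond the scatter) as a second step beyond the scatter in the same direction as the first. Nothing measured here accounts for these numbers.

On these data alone, in these steps the chain and the group at its end change together, so their separate contributions remain open. Also open, as far as these compounds go, is how a morpholin-4-yl group or a pyrrolidin-1-yl group at the chain end would compare with piperidin-1-yl.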